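A few compounds are considered here, and "the series" means these few. Any claim that something is new, unique, unknown or untested is made for them only; others in the source may bear on it.

Measured compounds:
- compound 1, `COC(=O)/C(=C/c1ccccc1)CN1C(=O)[C@@H](OC)[C@H]1c1ccc(Cl)cc1`, 15300 nM
- compound 2, `CCOC(=O)/C(=C/c1ccccc1)CN1C(=O)[C@@H](OC)[C@H]1c1ccc(Cl)cc1`, 12700 nM

Both numbers come from a functional assay on MCF7 cells (Homo sapiens) for antiproliferative activity, read by MTT assay, with a stated time of 48 h; on this read-out higher numbers stand for weaker inhibition and lower numbers for stronger inhibition. Compound 2 has the lowest of the two numbers in this assay, and its nearest neighbour is compound 1, with the step of a 1.2-fold lower number from compound 1 to compound 2 (0.08 log units; within the scatter), so the two cannot be told apart on these numbers. The only structural difference between them is the methyl in place of hydrogen on a saturated chain carbon bound to an oxygen next to a carbonyl group.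

Compound 3, `CCOC(=O)/C(=C/c1ccccc1)CN1C(=O)[C@@H](OC)[C@H]1c1ccc(F)cc1`, is not yet measured. It differs from compound 2 as follows: fluoro in place of chloro on an aromatic carbon, the aromatic ring that carries it being otherwise unchanged. Among the compounds with values here, no measured pair varies this halogen; the single step available, from compound 1 to compound 2, concerns the ester and says nothing about the aromatic substituent. There is therefore no basis in these numbers for expecting a step beyond the scatter in either direction, and the range must stay wide.

Compound 3 is accordingly expected at about 14000 nM, between 5000 nM and 40000 nM, which means an expected step of a 1.1-fold higher number from compound 2 to compound 3 (0.04 log units; within the scatter).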

Compound 3, half-maximal inhibitory concentration: 18800 nM
Compound 3: middle estimate off by 1.3-fold (0.13 log units), on the low side; low and high end bracket the measured number.
By their numbers in this assay, from the lowest: compounds 2, 1 and 3 (each within the scatter of the next).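

In this assay, within the data shown here, the change from 4-chlorophenyl to 4-fluorophenyl gives a 1.5-fold higher number from compound 2 to compound 3 (0.17 log units; within the scatter) and provides the first reading on the aromatic ring, since the earlier pair varied only the ester. On an aromatic carbon para to a large group, chloro and fluoro therefore cannot be told apart on these numbers, and exchanging one halogen for the other does not produce a step beyond the scatter. No measurement in hand bears on the cause of this result or on what the halogen contributes at this place.

Whether any halogen is needed here remains open, as the compounds shown do not reveal what hydrogen, a methoxy group or an amine would give in its place. Also open, going by these compounds, are a carboxylic acid or a longer chain in place of the methyl and ethyl esters, and any replacement of the unsubstituted phenyl group or of the methoxy group on the shared core.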